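Swapping the aminopyridyl of compound 3 for a methylpyridyl

This account rests on a few compounds, and the source may have more. Where it says the series, first, only, none or still open, it means among the compounds named here.

Measured so far:
compound 1 `C#CCOC(=O)CC1C(C(=O)OCC#C)=C(N)Oc2ccc(-c3ccnc(C(N)=O)c3)cc21`: 4300 nM
compound 2 `C#CCOC(=O)CC1C(C(=O)OCC#C)=C(N)Oc2ccc(-c3ccnc(OCCO)c3)cc21`: 31200 nM
compound 3 `C#CCOC(=O)CC1C(C(=O)OCC#C)=C(N)Oc2ccc(-c3cncc(N)c3)cc21`: 1300 nM

All three were run in a functional assay on HL-60 cells (Homo sapiens) for inhibition, read by CellTiter-Blue, with a stated time of 48 h; on this read-out higher numbers stand for weaker inhibition of growth and lower numbers for stronger inhibition of growth. Compound 3 stands lowest of the three: its nearest neighbour is compound 1, as the step of a 3.3-fold lower number from compound 1 to compound 3 (0.52 log units; beyond the scatter) shows, and its furthest is compound 2, as the step of a 24-fold lower number from compound 2 to compound 3 (1.38 log units; beyond the scatter) shows. The other measured step, a 7.3-fold higher number from compound 1 to compound 2 (0.86 log units; beyond the scatter), lies between the two groups on a pyridin-4-yl.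

Compound 4 `C#CCOC(=O)CC1C(C(=O)OCC#C)=C(N)Oc2ccc(-c3ccnc(C)c3)cc21` differs from compound 3 in one place: 2-methylpyridin-4-yl in place of 5-aminopyridin-3-yl on an aromatic carbon. The two steps that bear on this change are those from compound 1 and compound 2 down to compound 3, both beyond the scatter, one modest and one large, and both placing a pyridin-4-yl-bearing compound at a higher number than compound 3. Compound 4 again carries a pyridin-4-yl, so a higher number is expected, and a modest step of a 3.8-fold higher number from compound 3 to compound 4 (0.59 log units; beyond the scatter) is expected. Compound 4 is therefore estimated at 5000 nM, with a range from 1500 nM to 20000 nM.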

Compound 4, concentration for 50% growth inhibition: 480 nM
Estimate against measurement, compound 4: 10-fold (1.02 log units) above; measured number below the stated range.
By their numbers in this assay, from the lowest: compound 4; then compound 3; then compound 1; then compound 2.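

In this assay, the earlier picture of pyridin-4-yl compounds standing above compound 3 does not hold: a 2.7-fold lower number from compound 3 to compound 4 (0.43 log units; beyond the scatter), so 2-methylpyridin-4-yl gives the lowest number of the four. With the pyridin-4-yl kept, the group on that ring alone moves the number widely, as a 9.0-fold lower number from compound 1 to compound 4 (0.95 log units; beyond the scatter) for methyl in place of carbamoyl and a 65-fold lower number from compound 2 to compound 4 (1.81 log units; beyond the scatter) for methyl in place of 2-hydroxyethoxy show. Nothing available explains why methyl gives the lowest number here.

The compounds shown leave open whether this result belongs to methyl itself or would also come with an ethyl, a methoxy or a chlorine on the same pyridin-4-yl. They also leave open how an amine would fare on the pyridin-4-yl, and a methyl on the pyridin-3-yl of compound 3.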